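The source may report more compounds than this note shows. Statements on the series, on what has been measured and on what is new or still open speak of the compounds shown alone.

In an ADME assay for permeability (on this read-out lower numbers stand for lower permeability and higher numbers for higher permeability), three compounds have been measured. Compound 1 `CC[C@@H](c1ccccc1)n1nc(C(=O)NC)cc1C(=O)N[C@H]1[C@@H]2C[C@H](O)C[C@@H]21` gives 230 nm/s, compound 2 `CC[C@@H](c1ccccc1)n1nc(C(=O)NC)cc1C(=O)N[C@H]1CC[C@H](O)CC1` gives 70 nm/s, and compound 3 `CCCNC(=O)c1cc(C(=O)NC)nn1[C@@H](C)c1ccccc1` gives 560 nm/s, which is the highest of the three: it stands above compound 1 by a margin beyond the scatter and above compound 2 by a still wider one. For the measured compounds named here, the only step between measured compounds that differ in a single place is a 3.3-fold lower number from compound 1 to compound 2 (0.52 log units; beyond the scatter), where one saturated ring system replaces another on an amide-type nitrogen.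

Going by the values given here, compound 4 `CNC(=O)c1cc(C(=O)NC)n([C@@H](C)c2ccccc2)n1` differs from compound 3 in one place. hydrogen in place of ethyl on a saturated chain carbon bound to an amide-type nitrogen None of the measured steps touches this chain; the step from compound 1 to compound 2 concerns a different part of the molecule and gives no direct guide. Shortening this chain is therefore expected to give at most a modest lowering, and the step from compound 3 to compound 4 is expected to be a 1.6-fold lower number from compound 3 to compound 4 (0.20 log units; within the scatter), possibly within the scatter. Compound 4 is thus expected to show 350 nm/s in this assay, with a range from 180 nm/s to 600 nm/s.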

Compound 4, apparent permeability: 280 nm/s
For compound 4 the middle estimate is 1.3-fold (0.10 log units) above the measured one, within the range that was stated.
By their numbers in this assay, from the lowest: compound 2; then compounds 1, 4 and 3 (each within the scatter of the next, the first and the last beyond it).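

In this assay, for the compounds shown here, a 2.0-fold lower number from compound 3 to compound 4 (0.30 log units; within the scatter) is the first reading at this position, where propylcarbamoyl gives way to methylcarbamoyl. Going by these compounds alone, it shows that, for this pair, removing an ethyl from the chain leaves the two numbers within the usual scatter of each other, whereas the only earlier step, a 3.3-fold lower number from compound 1 to compound 2 (0.52 log units; beyond the scatter), concerned a ring change elsewhere and lay beyond it. The information at hand offers no explanation for the size of this step.

As far as these compounds go, how a longer chain such as butyl, or a chain ending in an amine or a carboxylic acid, would read at this position remains open. So does whether the same change from propyl to methyl would give a similar step on the core of compound 1 or compound 2.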